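Replacing the imidazole of compound 3 with an aminomethyl group

A few compounds are considered here, and "the series" means these few. Any claim that something is new, unique, unknown or untested is made for them only; others in the source may bear on it.

Compound 1, `O=S(=O)(Nc1cccc2c1CCCC2c1c[nH]cn1)c1ccc2ccccc2c1`, gives 214 nM in an assay on isolated protein (Cricetulus griseus) for binding affinity to Alpha-1B adrenergic receptor (Mesocricetus auratus), read by radioligand binding; on this read-out higher numbers stand for weaker inhibition and lower numbers for stronger inhibition.
Compound 2, `COc1ccc2c(c1NS(C)(=O)=O)CCCC2c1c[nH]cn1`, gives 1700 nM in this assay.
Compound 3, `CCS(=O)(=O)Nc1cccc2c1CCCC2c1c[nH]c(C)n1`, gives only a limit of < 10000 nM in this assay.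

Among the three measured compounds, compound 3 is the one for which no number is known, only a limit (the limit of < 10000 nM in this assay, at which 1 of the 3 values shown sits). Compound 1 and compound 2 have numbers, and compound 2 sits at the weaker end of the two.

Compound 4, `CCS(=O)(=O)Nc1cccc2c1CCCC2CN`, differs from compound 3 in one place: aminomethyl in place of 2-methyl-1H-imidazol-4-yl on a saturated ring carbon. The five-membered aromatic ring with its two nitrogens leaves, and a short chain with a single nitrogen takes its place on the saturated ring carbon. Going by the values given here, no measured pair shows this change, so its size is not known from the data.

The step that the limit leaves unreadable from compound 3 to compound 4 is expected to lie in the weaker direction, beyond the scatter. Compound 4 is estimated at 5000 nM, within a range from 800 nM to 30000 nM, with a real chance that only a limit is reported.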

Compound 4, inhibition constant: < 10000 nM
Compound 4: a limit, no number (the forecaster's own chance of this, stated with the estimate: 45%); the middle value is on the limit's open side.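

Compound 3 and compound 4 are both reported only as a limit, so no step can be read between them: the limit of < 10000 nM in this assay, at which 2 of the 4 values shown sit. The compounds shown leave open how far, and in which direction, aminomethyl in place of 2-methyl-1H-imidazol-4-yl shifts the result in this assay.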